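Swapping the aryl group on the piperazine of compound 2

The source may report more compounds than this note shows. Statements on the series, on what has been measured and on what is new or still open speak of the compounds shown alone.

Of the compounds shown here, two that share a core have so far been tested in a functional assay on A549 cells (Homo sapiens) for inhibition, read by MTT assay, with a stated time of 72 h; a lower number here means a stronger inhibitor, a higher number a weaker inhibitor. Compound 1 `O=C1Nc2ccc(F)cc2/C1=N/NC(=S)N1CCN(c2ccccc2)CC1` carries a fluorine on the core and a plain phenyl on the ring nitrogen, and in this assay compound 1 gives 20700 nM. Compound 2 `O=C1Nc2ccc(Cl)cc2/C1=N/NC(=S)N1CCN(c2ccc(Cl)cc2)CC1` carries a chlorine on the core and a 4-chlorophenyl on the ring nitrogen, and in this assay compound 2 gives 8180 nM. Compound 2 stands with the lowest of the two numbers, and its gap to compound 1 lies beyond the usual scatter; since the two differ in two places, no single change can be credited for that gap.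

Compound 3 `O=C1Nc2ccc(Cl)cc2/C1=N/NC(=S)N1CCN(c2ccccc2[N+](=O)[O-])CC1` is built from compound 2 by one change: 2-nitrophenyl in place of 4-chlorophenyl on an amine nitrogen in a ring. Among the measured compounds shown here, no pair of measured compounds isolates a change of this kind, so there is nothing to tell the direction of the step. The estimate for compound 3 in this assay is 9000 nM, with a range from 3000 nM to 30000 nM, meaning a step of a 1.1-fold higher number from compound 2 to compound 3 (0.04 log units; within the scatter) that is expected to stay within or near the scatter.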

Compound 3, half-maximal inhibitory concentration: 5580 nM
Beside the measured number, compound 3's estimate is 1.6-fold (0.21 log units) above it; measured number inside the range.
By their numbers in this assay, from the lowest: compounds 3 and 2 (each within the scatter of the next); then compound 1.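

Among the compounds shown here, this is the first step that changes only one place, the aryl group on an amine nitrogen in a ring, so it can be read where the gap between compound 1 and compound 2 could not. In this assay, the exchange of 4-chlorophenyl for 2-nitrophenyl gives a 1.5-fold lower number from compound 2 to compound 3 (0.17 log units; within the scatter), so a different aryl group with more heavy atoms and 2 hydrogen-bond acceptors in place of none leaves the number within the scatter on this chlorine-bearing core. Nothing available here accounts for this outcome, and this single step cannot separate the identity of the substituent from its place on the phenyl ring.

Still open, as far as these compounds go, is what 2-chlorophenyl or 4-nitrophenyl would give at this nitrogen, which would pull those two factors apart, and whether a plain phenyl on the same chlorine-bearing core would fall within the scatter of compound 2 as well. From the compounds shown here alone, it is equally open whether an aryl group carrying an amine or a carboxylic acid, or a benzyl group in place of the directly attached aryl ring, would move the number beyond the scatter.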